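Naphthol series: sulfamoyl for carboxy at the ring position

The source may hold more compounds than are shown below. What is called first, only, known or untested is meant among the compounds shown, and "the series" means these compounds.

Measured so far in an assay on RBL-1 cells with Polyunsaturated fatty acid 5-lipoxygenase (Rattus norvegicus) as the target; a higher number here means a weaker inhibitor, a lower number a stronger inhibitor:
- compound 1 `Cn1ccnc1Cc1ccc2ccccc2c1O`: 3500 nM
- compound 2 `Oc1c(Cc2ccccc2)cc(-c2ccccc2)c2ccccc12`: 56 nM
- compound 3 `O=C(O)c1cc(Cc2ccccc2)c(O)c2ccccc12`: 5800 nM

Compound 3 gives the highest number of the three. Its nearest neighbour is compound 1, and the two lie within the scatter of each other, so no order between them can be claimed. Compound 2 is far stronger; the single-point step a 100-fold higher number from compound 2 to compound 3 (2.02 log units; beyond the scatter) shows that placing carboxy on the aromatic carbon in place of phenyl costs a great deal.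

Compound 4 `NS(=O)(=O)c1cc(Cc2ccccc2)c(O)c2ccccc12` differs from compound 3 in one place: sulfamoyl in place of carboxy on an aromatic carbon. Among the compounds with values here, no measured step bears directly on this exchange. Within the data shown here, the only step in hand, from compound 2 to compound 3, compares phenyl with carboxy, not carboxy with sulfamoyl, so it gives no direction for the present change. Both groups that leave and enter carry a hydrogen-bond donor and one or two acceptors, and the rest of the core is unchanged, so the working expectation is a step of a 1.2-fold lower number from compound 3 to compound 4 (0.06 log units; within the scatter) in this assay, essentially none beyond the scatter. Among the measured compounds shown here, compound 4 is therefore estimated at 5000 nM, with a range from 1200 nM to 20000 nM; the range is wide, since no measured step covers this exchange.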

Compound 4, half-maximal inhibitory concentration: 9400 nM
Compound 4: the middle estimate sits 1.9-fold (0.27 log units) below what was measured; low and high end bracket the measured number.
By their numbers in this assay, from the lowest: compound 2; then compounds 1, 3 and 4 (each within the scatter of the next, the first and the last beyond it).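

In this assay, sulfamoyl in place of carboxy on this aromatic carbon, para to a hydroxy group, gives a 1.6-fold higher number from compound 3 to compound 4 (0.21 log units; within the scatter), so the two groups cannot be ordered at this position. Sulfamoyl in place of phenyl gives a 170-fold higher number from compound 2 to compound 4 (2.22 log units; beyond the scatter), a large loss like that of a 100-fold higher number from compound 2 to compound 3 (2.02 log units; beyond the scatter), so the cost of removing phenyl now appears with two different replacements and is not particular to carboxy. The data offer no explanation for either large step or for the lack of a clear difference between carboxy and sulfamoyl.

Going by these compounds, it remains open whether the low number of compound 2 is particular to phenyl at this position, or whether a methyl group, a methoxy group or a simple hydrogen on the same aromatic carbon would also avoid the loss seen with carboxy and sulfamoyl. On these data alone, it is also open whether the large phenyl steps and the small carboxy-to-sulfamoyl step would hold if the benzyl group were exchanged for a shorter chain such as ethyl.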